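Swapping a ring hydrogen for ethoxycarbonyl on the shared core

The source may report more compounds than this note shows. Statements on the series, on what has been measured and on what is new or still open speak of the compounds shown alone.

Compound 1, `O=C(CCCCC1CCSS1)NCc1cn(CCCOc2ccc3ccc(=O)oc3c2)nn1`: 37.8%
Compound 2, `CC(=O)c1cc2ccc(OCCCn3cc(CNC(=O)CCCCC4CCSS4)nn3)cc2oc1=O`: 34.6%

Of the compounds shown here, two have so far been measured in a functional assay on PC-12 cells (Rattus norvegicus) for cytotoxicity, read by MTT assay, with stated times of 3 h and 2 h, tested at 0.1 uM; on this read-out higher numbers stand for a stronger effect at the one concentration tested and lower numbers for a weaker effect. Compound 1 gives 37.8%, the highest of the two numbers, while compound 2 gives 34.6%; the step of a number 3.2 percentage points lower from compound 1 to compound 2 (within the scatter) is within the scatter, so the two compounds cannot be told apart on this read-out.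

The next compound, compound 3 `CCOC(=O)c1cc2ccc(OCCCn3cc(CNC(=O)CCCCC4CCSS4)nn3)cc2oc1=O`, is reached from compound 1 by a single change: ethoxycarbonyl in place of hydrogen on an aromatic carbon. Going by the values given here, the one measured step that bears on this change is the one from compound 1 to compound 2, where acetyl replaced hydrogen on the same aromatic carbon of the shared core of compound 1; that step, a number 3.2 percentage points lower from compound 1 to compound 2 (within the scatter), stayed within the scatter. With ethoxycarbonyl entering at the same place, no step beyond the scatter is expected in this assay either way. Compound 3 is therefore expected to give about 35%, with a range from 25% to 45%, which means an expected step of a number 2.8 percentage points lower from compound 1 to compound 3 (within the scatter).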

Compound 3, a percentage reported as activity, at one concentration (the size of the read-out at that concentration, not a potency): 28%
Compound 3: middle estimate off by 7 percentage points, on the high side; measured number inside the range.
By their numbers in this assay, from the lowest: compounds 3, 2 and 1 (each within the scatter of the next).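

In this assay, the aromatic carbon has now carried a second group, and ethoxycarbonyl, with its 5 heavy atoms, gives a number 9.8 percentage points lower from compound 1 to compound 3 (within the scatter), so that neither it nor acetyl can be told apart from hydrogen at this position. Putting ethoxy in place of methyl on the carbonyl carbon gives a number 6.6 percentage points lower from compound 2 to compound 3 (within the scatter), which shows that the two groups at this position cannot be told apart from each other either. All three compounds therefore lie within the scatter of one another, and nothing available explains where their numbers fall.

Going by these compounds, it remains open whether a carboxylic acid, an amine or a longer ester such as butoxycarbonyl on this same aromatic carbon would produce a step beyond the scatter. Also unresolved is how the three compounds would compare at other concentrations, as a reading at a single concentration gives the size of the effect there and not a potency.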